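The compounds below may be only part of what the source reports. "The series", "measured", "known", "first", "only" and "open" are said of these compounds alone.

Compound 2 `O=C(CCN1C(=O)CSc2ccccc21)NCCCN1CCN(c2ccc(C(F)(F)F)cc2)CC1` and compound 1 `O=C(CCN1C(=O)CSc2ccccc21)NCCCN1CCN(c2ccc([N+](=O)[O-])cc2)CC1` share one core and differ only at the aromatic ring on the piperazine nitrogen. In a functional assay on MDA-MB-231 cells (Homo sapiens) for inhibition, read by sulforhodamine B assay, with a stated time of 48 h (on this read-out higher numbers stand for weaker inhibition of growth and lower numbers for stronger inhibition of growth), compound 1 gives only a limit, > 100000 nM. In this assay compound 2 gives 20400 nM, the single number shown, so compound 2 stands as the one measured point. Within the data shown here, the step of an at least 4.9-fold lower number from compound 1 to compound 2 (0.69 log units; beyond the scatter) is the only measured change, and it rests on (the limit of > 100000 nM in this assay, at which 1 of the 2 values shown sits). Compound 3 `O=C(CCN1C(=O)CSc2ccccc21)NCCCN1CCN(c2ccccc2F)CC1` differs from compound 2 by 2-fluorophenyl in place of 4-(trifluoromethyl)phenyl on an amine nitrogen in a ring. That step touches the same ring as the measured step, but the measured step bears on it only loosely, since it replaced one group on the ring and here a different group goes to a different place. The expectation is therefore a step of a 2.0-fold higher number from compound 2 to compound 3 (0.29 log units; within the scatter), and compound 3 is estimated at 40000 nM, between 14000 nM and 100000 nM.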

Compound 3, concentration for 50% growth inhibition: 4600 nM
Beside the measured number, compound 3's estimate is 8.7-fold (0.94 log units) above it; the measured number lies below the stated range.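

In this assay, the group on this amine nitrogen in a ring still has room to shift the read-out, with the step of a 4.4-fold lower number from compound 2 to compound 3 (0.65 log units; beyond the scatter) lying beyond the scatter. Compound 3 is the strongest growth inhibitor of the three shown, as its steps to both of the others are printed as beyond the scatter. The other new step, an at least 21-fold lower number from compound 1 to compound 3 (1.33 log units; beyond the scatter), starts from a limit and not from a number, and so gives only a bound: the limit of > 100000 nM in this assay, at which 1 of the 3 values shown sits.

The substituent and its place on the phenyl ring changed together in this step, so the compounds shown do not separate the two. They also leave open how 4-fluorophenyl, 2-chlorophenyl or unsubstituted phenyl on the same nitrogen would read.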